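Shifting the Imidazole Attachment Point on a Shared Core

The source may report more compounds than this note shows. Statements on the series, on what has been measured and on what is new or still open speak of the compounds shown alone.

compound 1 `N#Cc1c(N)nc(SCc2ccn[nH]2)c(C#N)c1-c1ccc(OCC2CC2)cc1`: 84 nM
compound 2 `N#Cc1c(N)nc(SCc2ncc[nH]2)c(C#N)c1-c1ccc(OCC2CC2)cc1`: 9.5 nM

In a functional assay on CHO cells for agonist activity at adenosine receptor A2b (Homo sapiens), read by AlphaScreen and cAMP accumulation (a higher number here means that more compound is needed for the effect, a lower number that less compound is needed), compound 2 stands lowest of the two numbers, separated from compound 1 by an 8.8-fold lower number from compound 1 to compound 2 (0.95 log units; beyond the scatter). Compound 3 `N#Cc1c(N)nc(SCc2cnc[nH]2)c(C#N)c1-c1ccc(OCC2CC2)cc1` differs from compound 2 by 1H-imidazol-5-yl in place of 1H-imidazol-2-yl on a saturated chain carbon bound to a sulfur. Among the compounds with values here, that measured step exchanged one ring for another, so it bears only loosely on a move of the attachment point within the same ring; no measured pair shows such a move. The step of a 1.6-fold higher number from compound 2 to compound 3 (0.20 log units; within the scatter) is expected to be small, of either sign. Compound 3 is estimated at 15 nM, within 4 nM to 55 nM.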

Compound 3, half-maximal effective concentration: 139 nM
Compound 3: the middle estimate sits 9.3-fold (0.97 log units) below what was measured; the whole stated range lies below it.
By their numbers in this assay, from the lowest: compound 2; then compounds 1 and 3 (each within the scatter of the next).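

In this assay, the same atoms joined differently give a 15-fold higher number from compound 2 to compound 3 (1.17 log units; beyond the scatter), so this place on a saturated chain carbon bound to a sulfur distinguishes 1H-imidazol-2-yl from 1H-imidazol-5-yl, not merely an imidazole from a pyrazole. The imidazole ring alone therefore does not secure the low number of compound 2, as a 1.7-fold higher number from compound 1 to compound 3 (0.22 log units; within the scatter) leaves 1H-imidazol-5-yl within the scatter of 1H-pyrazol-5-yl. No available evidence accounts for the difference between these isomers.

On these data alone, it remains open whether a methyl group on the 1H-imidazol-2-yl ring, or a longer chain carrying that ring, would preserve the number of compound 2.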